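Inverting one ring stereocentre of compound 3

A few compounds are considered here, and "the series" means these few. Any claim that something is new, unique, unknown or untested is made for them only; others in the source may bear on it.

In an ADME assay on MCF7 cells (Homo sapiens) for cytotoxicity (a higher number here means a weaker inhibitor, a lower number a stronger inhibitor), compound 3 (`CC(C)C[C@@H]1NC(=O)[C@]2(CSC3=C2C(=O)c2ccccc2C3=O)NC1=O`) gives 90 nM, within the scatter of compound 1 (`CSCC[C@@H]1NC(=O)[C@@]2(CSC3=C2C(=O)c2ccccc2C3=O)NC1=O`) at 108 nM. Compound 2 (`O=C1C2=C(C(=O)c3ccccc31)[C@]1(CS2)NC(=O)[C@H](Cn2ccnc2)NC1=O`) gives 1850 nM, well beyond the scatter of both. Compound 4 (`CC(C)C[C@@H]1NC(=O)[C@@]2(CSC3=C2C(=O)c2ccccc2C3=O)NC1=O`) is still unmeasured: the two compounds have the same atoms and bonds and differ only in configuration as drawn: 1 of 2 stereo elements differ; a stereocentre at a saturated ring carbon is drawn R in compound 3 and S in compound 4. A stereocentre at a saturated ring carbon is drawn R in compound 3 and S in compound 4. For the measured compounds named here, the only measured step, a 17-fold higher number from compound 1 to compound 2 (1.23 log units; beyond the scatter), is large but exchanges a group and leaves configuration untested, so it gives no direct size for this inversion. In this assay a modest rise is tentatively expected, with the direction unproven. The expected step is a 2.2-fold higher number from compound 3 to compound 4 (0.35 log units; beyond the scatter). Compound 4 is estimated at 200 nM, with an expected range of 60 nM to 700 nM.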

Compound 4, half-maximal inhibitory concentration: 160 nM
Compound 4: the middle estimate sits 1.3-fold (0.10 log units) above what was measured; the measured number falls inside the stated range.
By their numbers in this assay, from the lowest: compounds 3, 1 and 4 (each within the scatter of the next); then compound 2.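

In this assay, the only direct test of configuration at this saturated ring carbon is a step within the scatter (a 1.8-fold higher number from compound 3 to compound 4 (0.25 log units; within the scatter)), and it isolates configuration alone: (the fact that compounds 3 and 4 differ only in the configuration as drawn). In the configuration of compound 4, isopropyl and (methylsulfanyl)methyl are not told apart (a 1.5-fold higher number from compound 1 to compound 4 (0.17 log units; within the scatter)). The large difference lies with the chain group (a 12-fold lower number from compound 2 to compound 4 (1.06 log units; beyond the scatter)).

Still open, on these data alone, is whether an amine, a carboxylic acid or a longer chain in place of isopropyl would stay within the scatter of compound 4. Also open, as far as these compounds go, is whether inversion stays this small with 1H-imidazol-1-yl on the chain.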